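The source may report more compounds than this note shows. Statements on the series, on what has been measured and on what is new or still open speak of the compounds shown alone.

Working notes on the series. For the measured compounds named here, compound 1 `COC(=O)/C(=C/c1ccccc1)CN1C(=O)[C@@H](OC)[C@H]1c1ccc(Cl)cc1` is the only member with a number to its name: in an ADME assay on cells (Epithelial cell, Homo sapiens) for antiproliferative activity, read by MTT assay, with a stated time of 48 h (on this read-out lower numbers stand for stronger inhibition and higher numbers for weaker inhibition), compound 1 gives 37900 nM, a weak level of inhibition. Compound 2 `CCOC(=O)/C(=C/c1ccccc1)CN1C(=O)[C@@H](OC)[C@H]1c1cccc([N+](=O)[O-])c1` is recorded in this assay only as "not toxic" (no number reported), so it offers no number to set beside compound 1. On the numbers shown, compound 1 therefore stands alone, with nothing to rank it against.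

Compound 3 `COC(=O)/C(=C/c1ccccc1)CN1C(=O)[C@@H](OC)[C@H]1c1ccc(OC)cc1` differs from compound 1 by methoxy in place of chloro on an aromatic carbon. Going by the values given here, no step between two measured compounds is available, so the effect of this change in this assay is untested. Given that compound 1 sits at 37900 nM and compound 2 returned no number, compound 3 is expected to stay at a weak level, with no move beyond the scatter and, if anything, a drift toward weaker inhibition. Compound 3 is estimated at 45000 nM, within a range of 15000 nM to 150000 nM. The expected step is a 1.2-fold higher number from compound 1 to compound 3 (0.07 log units; within the scatter).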

Compound 3, half-maximal inhibitory concentration: "not toxic" (no number reported)
Compound 3 has no reported number here; the estimate stays without a comparison.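

For the compounds shown here, compound 3, like compound 2, carries no number in this assay and so no step from compound 1 can be read. The compounds shown leave open how 4-chlorophenyl to 4-methoxyphenyl bears on inhibition. No supporting data bear on this result.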